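Compound 3 to compound 4: one ring exchanged

The compounds below may be only part of what the source reports. "The series", "measured", "known", "first", "only" and "open" are said of these compounds alone.

compound 1 `COc1cc(Nc2ncnc3c(NC(=O)Nc4ccc(C)c(C)c4)cccc23)cc(OC)c1`: 8.8 nM
compound 2 `COc1cc(Nc2ncnc3c(NC(=O)Nc4ccccc4Cl)cccc23)cc(OC)c1`: 356 nM
compound 3 `COc1cc(Nc2ncnc3c(NC(=O)Nc4cc(C)cc(C)c4)cccc23)cc(OC)c1`: 10100 nM

These numbers come from a functional assay on RT-112 cells (Homo sapiens) for antiproliferative activity, read by MTT assay, with a stated time of 72 h; on this read-out higher numbers stand for weaker inhibition of growth and lower numbers for stronger inhibition of growth. Compound 3 gives 10100 nM, the highest number of the three and so the weakest inhibition of growth. Compound 4 `COc1cc(Nc2ncnc3c(NC(=O)Nc4ccc(F)cc4F)cccc23)cc(OC)c1` has not yet been measured. It keeps the shared core of compound 3 and differs in one group: 2,4-difluorophenyl in place of 3,5-dimethylphenyl on an amide-type nitrogen.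

Within the data shown here, three measured steps bear on this change, all exchanges at that same amide-type nitrogen, and all large: a 40-fold higher number from compound 1 to compound 2 (1.61 log units; beyond the scatter), a 1100-fold higher number from compound 1 to compound 3 (3.06 log units; beyond the scatter) and a 28-fold higher number from compound 2 to compound 3 (1.45 log units; beyond the scatter). Among these compounds, then, the group at this place matters a great deal. None of them carries the entering 2,4-difluorophenyl, so the data cannot fix the size of the step. The closest comparison is the 2-chlorophenyl of compound 2, also a halogen-bearing ring, and compound 2 gives 356 nM. On that comparison, a large step towards a lower number is expected, though this rests on a single compound. The estimated step is a 34-fold lower number from compound 3 to compound 4 (1.53 log units; beyond the scatter). The expected value for compound 4 is 300 nM, within an estimated range of 30 nM to 3000 nM.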

Compound 4, concentration for 50% growth inhibition: 2460 nM
Compound 4: middle estimate off by 8.2-fold (0.91 log units), on the low side, and the stated range covers the measured number.
By their numbers in this assay, from the lowest: compound 1; then compound 2; then compound 4; then compound 3.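

In this assay, putting 2,4-difluorophenyl in place of 3,5-dimethylphenyl gives only a 4.1-fold lower number from compound 3 to compound 4 (0.61 log units; beyond the scatter), so this exchange recovers far less than the earlier 2-chlorophenyl compound suggested. Carrying halogen on the ring is therefore not enough to place a compound at one level here: the two halogen-bearing rings are themselves separated by a 6.9-fold higher number from compound 2 to compound 4 (0.84 log units; beyond the scatter), a real difference between rings that both carry halogen and have no hydrogen-bond donors or acceptors. The 3,4-dimethylphenyl ring also remains well ahead of the new ring, with a 280-fold higher number from compound 1 to compound 4 (2.45 log units; beyond the scatter), and nothing available here accounts for any of these differences.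

Four aryl groups at one amide-type nitrogen, with a single fluorine-bearing ring among them, cannot separate the effect of which atoms a ring carries from the effect of where it carries them. Also open, from the compounds shown here alone, is how this read-out would respond to a plain unsubstituted phenyl, a methoxyphenyl, a trifluoromethylphenyl or a pyridyl ring at this nitrogen, any of which would show whether the low number of compound 1 is a rare result or one shared by other rings.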